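Ring size and a methyl group on the amine substituent

The compounds below may be only part of what the source reports. "The series", "measured", "known", "first", "only" and "open" are said of these compounds alone.

Compound 1, `c1ccc(Cn2nnc3c(NC4CCCCC4)ncnc32)cc1`: 121 nM in an assay on cell membranes for binding affinity to adenosine receptor A1 (Bos taurus), read by radioligand binding; a lower number here means a stronger inhibitor, a higher number a weaker inhibitor
Compound 2, `c1ccc(Cn2nnc3c(NC4CCCC4)ncnc32)cc1`: 127 nM

Compound 2 is not set apart from compound 1: the step of a 1.0-fold higher number from compound 1 to compound 2 (0.02 log units; within the scatter) lies within the usual scatter of this assay, so the two numbers read as the same. In that step a cyclohexyl ring was swapped for a cyclopentyl ring on the nitrogen attached to the aromatic core, and the binding hardly moved.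

Compound 3, `CC1CCCC(Nc2ncnc3c2nnn3Cc2ccccc2)C1`, takes the next step from compound 2: 3-methylcyclohexyl in place of cyclopentyl on a nitrogen on an aromatic ring. Within the data shown here, the only measured step that bears on it is the one from compound 1 to compound 2, which shows that the size of the plain carbon ring on this nitrogen made no difference beyond the scatter. Among the measured compounds shown here, no measured pair speaks to the added methyl group on that ring, so its effect is unknown.

On that basis, the step of a 1.2-fold lower number from compound 2 to compound 3 (0.06 log units; within the scatter) is expected to be small, with no clear direction, and compound 3 is estimated at 110 nM in this assay, within a range from 40 nM to 320 nM.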

Compound 3, inhibition constant: 770 nM
For compound 3 the middle estimate is 7.0-fold (0.85 log units) below the measured one; the whole stated range lies below it.
By their numbers in this assay, from the lowest: compounds 1 and 2 (each within the scatter of the next); then compound 3.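

Once the ring carries a methyl group, the substituent on this nitrogen is no longer indifferent: ring size alone gave only a 1.0-fold higher number from compound 1 to compound 2 (0.02 log units; within the scatter), while adding a single methyl group to the cyclohexyl ring gives a 6.4-fold higher number from compound 1 to compound 3 (0.80 log units; beyond the scatter) in this assay, and a higher number here means weaker binding. The change from cyclopentyl to 3-methylcyclohexyl gives a 6.1-fold higher number from compound 2 to compound 3 (0.78 log units; beyond the scatter), a step of similar size, so across these three compounds the loss goes with the methyl group and not with the ring size. Nothing available explains why one added methyl group costs this much binding.

On these data alone, what remains open is whether any added group on the ring would do the same, or whether the loss is particular to methyl; a hydroxyl group, a fluorine atom or an ethyl group in its place would begin to separate those possibilities. As far as these compounds go, it is also open whether a ring is needed on this nitrogen at all, which an open chain such as hexyl, or an aromatic phenyl ring, would help to settle.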